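Predicting a nitrophenyl analogue of compound 1

The source may report more compounds than this note shows. Statements on the series, on what has been measured and on what is new or still open speak of the compounds shown alone.

Compound 1 `COc1ccc(C(=O)c2cc(OC)c(OC)c(OC)c2)cc1NC(=O)/C=C/c1ccc(OC)c(OC)c1`: 2500 nM
Compound 2 `COc1ccc(C(=O)c2cc(OC)c(OC)c(OC)c2)cc1NC(=O)/C=C/c1ccc(F)cc1`: 1800 nM
Compound 3 `COc1ccc(C(=O)c2cc(OC)c(OC)c(OC)c2)cc1NC(=O)/C=C/c1ccc(N)cc1`: 5600 nM

Of the compounds shown here, three sharing one core have been tested in a functional assay on HT-29 cells (Homo sapiens) for cytotoxicity, read by MTT assay, with a stated time of 72 h; a lower number here means a stronger inhibitor, a higher number a weaker inhibitor. Compound 1 stands second highest of the three numbers; its nearest neighbour is compound 2, with a 1.4-fold lower number from compound 1 to compound 2 (0.14 log units; within the scatter), and its furthest is compound 3, with a 2.2-fold higher number from compound 1 to compound 3 (0.35 log units; beyond the scatter). Between those two, a 3.1-fold higher number from compound 2 to compound 3 (0.49 log units; beyond the scatter).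

Compound 4 `COc1ccc(C(=O)c2cc(OC)c(OC)c(OC)c2)cc1NC(=O)/C=C/c1ccc([N+](=O)[O-])cc1` has not yet been measured. Relative to compound 1 the change is 4-nitrophenyl in place of 3,4-dimethoxyphenyl on a double-bonded chain carbon bound to a double-bonded chain carbon. For the measured compounds named here, two measured steps bear on it, since both also replace the 3,4-dimethoxyphenyl group of compound 1 on the same chain carbon: the step to compound 2 stayed within the scatter, while the step to compound 3 was modest and upward. Neither points to a large effect, so compound 4 is expected to land close to compound 1, with a 1.1-fold lower number from compound 1 to compound 4 (0.06 log units; within the scatter), most likely within the scatter. The estimate for compound 4 in this assay is 2200 nM, with a range from 900 nM to 5500 nM.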

Compound 4, half-maximal inhibitory concentration: 5100 nM
Beside the measured number, compound 4's estimate is 2.3-fold (0.37 log units) below it, and the stated range covers the measured number.
By their numbers in this assay, from the lowest: compounds 2 and 1 (each within the scatter of the next); then compounds 4 and 3 (each within the scatter of the next).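

In this assay, the nitro compound shows that not every replacement of the 3,4-dimethoxyphenyl group on this chain carbon stays within the scatter (a 2.0-fold higher number from compound 1 to compound 4 (0.31 log units; beyond the scatter)), and the modest gap also appears against the fluoro analogue (a 2.8-fold higher number from compound 2 to compound 4 (0.45 log units; beyond the scatter)). Nitro and amino on the aromatic carbon cannot be told apart (a 1.1-fold lower number from compound 3 to compound 4 (0.04 log units; within the scatter)), so compounds 3 and 4 now form a pair set modestly apart from compounds 1 and 2. Nothing given here accounts for that division of the four compounds.

As far as these compounds go, it remains open whether a carboxylic acid or a nitrile in place of the nitro group would join compounds 3 and 4 or compounds 1 and 2. A chloro or methoxy group on that aromatic carbon would test the same division.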